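This account rests on a few compounds, and the source may have more. Where it says the series, first, only, none or still open, it means among the compounds named here.

Measured compounds:
compound 1 `CCN1CCN(c2cc(C)c3cc(NC(=O)c4ccc[nH]4)ccc3n2)CC1`, 14700 nM
compound 2 `CNc1cc(C)c2cc(NC(=O)c3ccc(Cl)c(Cl)c3)ccc2n1`, 2520 nM

Both were tested in a functional assay on MCF7 cells (Homo sapiens) for antiproliferative activity, read by MTT assay, with a stated time of 72 h; a higher number here means a weaker inhibitor, a lower number a stronger inhibitor. Of the two numbers, compound 1 has the highest, and compound 2 lies beyond the scatter with its lower number, so compound 1 is the weaker of the pair. Compound 3 `CCN1CCN(c2cc(C)c3cc(NC(=O)c4ccccc4F)ccc3n2)CC1` has not yet been measured. It differs from compound 1 in one place: 2-fluorophenyl in place of 1H-pyrrol-2-yl on a carbonyl carbon. Among the measured compounds shown here, no step between measured compounds covers this change, so the expectation rests on the gap between compound 1 and compound 2 alone. A modest move toward a lower number is expected, as a 2.5-fold lower number from compound 1 to compound 3 (0.39 log units; beyond the scatter). For compound 3 the estimate is 6000 nM, ranging from 2000 nM to 18000 nM.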

Compound 3, half-maximal inhibitory concentration: 32600 nM
For compound 3 the middle estimate is 5.4-fold (0.74 log units) below the measured one, and the stated range ends below it.
By their numbers in this assay, from the lowest: compound 2; then compound 1; then compound 3.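

On the carbonyl carbon, this assay shows a 2.2-fold higher number from compound 1 to compound 3 (0.35 log units; beyond the scatter) when 2-fluorophenyl replaces 1H-pyrrol-2-yl, so the group held here does change the read-out, and this exchange moves it toward a weaker inhibitor. The exchange swaps a five-membered aromatic ring carrying a hydrogen-bond donor for a six-membered carbon ring carrying fluorine. Nothing measured here gives a reason for the rise. Still open, going by these compounds, is whether the fluorine, the ring size or the lost donor matters, as plain phenyl or furan-2-yl on this carbonyl carbon could help separate these.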